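The compounds below may be only part of what the source reports. "The series", "measured", "known", "first", "only" and "open" are said of these compounds alone.

Compound 1 `COc1cc(N2C(=O)[C@@H](Oc3ccccc3)[C@H]2c2cccc([N+](=O)[O-])c2)cc(OC)c1OC`: 30000 nM
Compound 2 `CCOC(=O)/C=C/c1ccc([C@@H]2[C@H](Oc3ccccc3)C(=O)N2c2cc(OC)c(OC)c(OC)c2)cc1`: 87000 nM

In a functional assay on MCF7 cells (Homo sapiens) for antiproliferative activity, read by MTT assay, with stated times of 24 h and 72 h (on this read-out higher numbers stand for weaker inhibition and lower numbers for stronger inhibition), compound 2 has the higher of the two numbers, and the gap to compound 1 lies beyond the scatter. Compound 3 `COc1cc(N2C(=O)[C@@H](Oc3ccccc3)[C@H]2c2ccc(S(C)(=O)=O)cc2)cc(OC)c1OC` carries methylsulfonyl in place of 2-(ethoxycarbonyl)ethenyl on an aromatic carbon. Going by the values given here, no single-place step between measured compounds is available as a guide. The expectation therefore leans on compound 1, which also lacks the 2-(ethoxycarbonyl)ethenyl and gives 30000 nM. A modest move toward stronger inhibition is expected, with an estimated step of a 2.9-fold lower number from compound 2 to compound 3 (0.46 log units; beyond the scatter). For compound 3 the estimated value is 30000 nM, with an expected range from 8000 nM to 100000 nM.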

Compound 3, half-maximal inhibitory concentration: 62000 nM
Estimate against measurement, compound 3: 2.1-fold (0.32 log units) below, within the range that was stated.
By their numbers in this assay, from the lowest: compound 1; then compounds 3 and 2 (each within the scatter of the next).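

In this assay, methylsulfonyl in place of 2-(ethoxycarbonyl)ethenyl on an aromatic carbon gives a 1.4-fold lower number from compound 2 to compound 3 (0.15 log units; within the scatter) and so does not separate these two groups at this place. Exchanging the whole aryl group, 4-(methylsulfonyl)phenyl in place of 3-nitrophenyl on a saturated ring carbon, gives a 2.1-fold higher number from compound 1 to compound 3 (0.32 log units; beyond the scatter) and leaves compound 1 with the lower number of that pair. Nothing at hand gives a cause for either step. On these data alone, whether an amine or a carboxylic acid on that aromatic carbon would shift the number beyond the scatter remains open.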